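This account rests on a few compounds, and the source may have more. Where it says the series, first, only, none or still open, it means among the compounds named here.

The measured compounds are compound 1 `CCc1cccc2c(OC)c(-c3occ(C)c3C(=O)OC)ccc12`, compound 2 `CCc1cccc2c(OC)c(-c3occ(C)c3C(=S)OC)ccc12` and compound 3 `CCOCc1c(C)coc1-c1ccc2c(CC)cccc2c1OC`. In a functional assay on A549 cells (Homo sapiens) for cytotoxicity, read by MTT assay, with a stated time of 72 h (a lower number here means that less compound is needed, a higher number that more compound is needed for the effect), compound 1 gives 1.5 ug/mL. In this assay compound 2 gives 6.2 ug/mL. For compound 3 this assay reports only a limit, > 10 ug/mL, and not a number (the limit of > 10 ug/mL in this assay, at which 1 of the 3 values shown sits).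

Compound 3 therefore stands at the floor of the measured range, reached by the steps of an at least 6.6-fold higher number from compound 1 to compound 3 (0.82 log units; beyond the scatter) and an at least 1.6-fold higher number from compound 2 to compound 3 (0.20 log units; that floor lies within the scatter). Compound 4 `CCc1cccc2c(OC)c(-c3occ(C)c3COC(=O)CCN(CC)CC)ccc12` differs from it by (2-(diethylamino)ethyl)carbonyl in place of ethyl on an oxygen on a saturated carbon. Among the compounds with values here, none of the measured steps alters this part of the structure, so no measured step bears directly on the change; the two steps ending at compound 3 tell only that it sits at the limit. The step of a number no higher from compound 3 to compound 4 (the limit leaves the size open) is thus expected to be small and of uncertain direction. Compound 4 is estimated at 10 ug/mL, with a range from 3 ug/mL to 30 ug/mL.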

Compound 4, concentration for half-maximal effect: > 10 ug/mL
Compound 4: only a limit was reported; the forecaster's own chance of this, stated with the estimate: 50%; the middle value sits exactly at the limit.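

In this assay compound 4 gives only the limit > 10 ug/mL and compound 3 also stands at a limit, so no step between them can be read: the limit of > 10 ug/mL in this assay, at which 2 of the 4 values shown sit.

The compounds shown leave open whether (2-(diethylamino)ethyl)carbonyl in place of ethyl changes the number at all.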